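Restoring an Oxolane-Bearing Arm on Compound 3

This account rests on a few compounds, and the source may have more. Where it says the series, first, only, none or still open, it means among the compounds named here.

Measured compounds:
Compound 1, `NC(=O)CN(CCC(c1ccccc1)c1ccccc1)C(=O)CN(CCC(c1ccccc1)c1ccccc1)C(=O)CNCC1CCCO1`, gives 3550 nM in an ADME assay on HL-60 cells (Homo sapiens) for cytotoxicity, with a stated time of 72 h; a lower number here means a stronger inhibitor of growth, a higher number a weaker inhibitor of growth.
Compound 2, `NC(=O)CN(CCC(c1ccccc1)c1ccccc1)C(=O)CNCCC(c1ccccc1)c1ccccc1`, gives 13200 nM in this assay.
Compound 3, `O=C(CNCCC(c1ccccc1)c1ccccc1)NCCC(c1ccccc1)c1ccccc1`, gives 12600 nM in this assay.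

Compound 3 stands second highest of the three numbers. Its nearest neighbour is compound 2, whose number lies within the usual scatter of its own, so the two cannot be told apart. Compound 1 gives a lower number than compound 3, and that gap is beyond the scatter.

Compound 4, `O=C(CN(CCC(c1ccccc1)c1ccccc1)C(=O)CNCC1CCCO1)NCCC(c1ccccc1)c1ccccc1`, differs from compound 3 by ((((oxolan-2-yl)methyl)amino)methyl)carbonyl in place of hydrogen on an amine nitrogen. The same change, run backwards, is already on record: a 3.7-fold higher number from compound 1 to compound 2 (0.57 log units; beyond the scatter). The remaining difference between compound 2 and compound 3 made no difference in this assay, as a 1.0-fold lower number from compound 2 to compound 3 (0.02 log units; within the scatter) shows, so the record from compound 1 to compound 2 bears directly on this step. The expected outcome is therefore a modest drop in the number, beyond the scatter, of roughly the size seen there: a 3.6-fold lower number from compound 3 to compound 4 (0.56 log units; beyond the scatter). Compound 4 is estimated at 3500 nM, likely between 1500 nM and 8000 nM.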

Compound 4, concentration for 50% growth inhibition: 23000 nM
Compound 4: the middle estimate sits 6.6-fold (0.82 log units) below what was measured; measured number above the stated range.
By their numbers in this assay, from the lowest: compound 1; then compounds 3, 2 and 4 (each within the scatter of the next).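

Placing ((((oxolan-2-yl)methyl)amino)methyl)carbonyl on the amine nitrogen of compound 3 leaves the two compounds within the scatter of each other, with a 1.8-fold higher number from compound 3 to compound 4 (0.26 log units; within the scatter). The size of this change therefore depends on the core that carries it: the same change on two cores in this assay, a 3.7-fold higher number (0.57 log units; beyond the scatter) from compound 1 to compound 2 and a 1.8-fold lower number (0.26 log units; within the scatter) from compound 4 to compound 3, 6.8-fold (0.83 log units) apart, beyond the scatter of two such steps. Carbamoylmethyl on the amide-type nitrogen, which made no measurable difference without the oxolane-bearing arm, matters once the arm is present, with a 6.5-fold higher number from compound 1 to compound 4 (0.81 log units; beyond the scatter): the same change on two cores in this assay, a 1.0-fold lower number (0.02 log units; within the scatter) from compound 2 to compound 3 and a 6.5-fold higher number (0.81 log units; beyond the scatter) from compound 1 to compound 4, 6.8-fold (0.83 log units) apart, beyond the scatter of two such steps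

The compounds shown leave open whether the oxolane ring itself matters in compound 1, or whether a cyclopentyl ring or a plain methyl group in its place would serve as well. They also leave open whether a longer chain carrying the same terminal amide would behave as carbamoylmethyl does.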